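The source may hold more compounds than are shown below. What is called first, only, known or untested is meant among the compounds shown, and "the series" means these compounds.

Three compounds share a common core and differ only in one group on a six-membered carbon ring. Compound 1 `CN(C)c1cccc(Nc2nccc(-c3cccnc3)n2)c1` carries a dimethylamino group there and in a functional assay for inhibition, with Homo sapiens as the target (a higher number here means a weaker inhibitor, a lower number a stronger inhibitor), compound 1 gives 1800 nM. Compound 2 `Clc1cccc(Nc2nccc(-c3cccnc3)n2)c1` carries a chloro group in its place, and in this assay compound 2 gives 1500 nM; the change gives a 1.2-fold lower number from compound 1 to compound 2 (0.08 log units; within the scatter). Compound 3 `c1cc(Nc2nccc(-c3cccnc3)n2)cc(OCCn2ccnc2)c1` carries a 2-(1H-imidazol-1-yl)ethoxy group, and in this assay compound 3 gives 100 nM, the lowest of the three numbers and thus the strongest inhibitor among them, as both an 18-fold lower number from compound 1 to compound 3 (1.26 log units; beyond the scatter) and a 15-fold lower number from compound 2 to compound 3 (1.18 log units; beyond the scatter) lie beyond the scatter.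

Compound 4 `CCOC(=O)c1cccc(Nc2nccc(-c3cccnc3)n2)c1` is not yet measured. It differs from compound 3 by ethoxycarbonyl in place of 2-(1H-imidazol-1-yl)ethoxy on an aromatic carbon. The two steps that bear on this change both point the same way: the 2-(1H-imidazol-1-yl)ethoxy group of compound 3 brought a large gain over the dimethylamino group of compound 1 and over the chloro group of compound 2, and compound 4 gives that group up for an ethoxycarbonyl group, which has no ring. Compound 4 is therefore expected to lose most of that gain and to fall back toward the numbers of compounds 1 and 2, a step of about a 15-fold higher number from compound 3 to compound 4 (1.18 log units; beyond the scatter). The expected value for compound 4 in this assay is 1500 nM, with a likely range from 500 nM to 5000 nM.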

Compound 4, half-maximal inhibitory concentration: 10500 nM
For compound 4 the middle estimate is 7.0-fold (0.85 log units) below the measured one; measured number outside the range, above it.
By their numbers in this assay, from the lowest: compound 3; then compounds 2 and 1 (each within the scatter of the next); then compound 4.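

In this assay this position proves able to move the number in both directions: ethoxycarbonyl gives up everything gained by the 2-(1H-imidazol-1-yl)ethoxy group, with a 110-fold higher number from compound 3 to compound 4 (2.02 log units; beyond the scatter) as the change, and it also falls past the two simpler groups, with a 7.0-fold higher number from compound 2 to compound 4 (0.85 log units; beyond the scatter) and a 5.8-fold higher number from compound 1 to compound 4 (0.77 log units; beyond the scatter) as the steps. Chloro and dimethylamino sit within the scatter of each other and could have looked like a floor for this series, but compound 4 is the weakest inhibitor of the four, so a group here can cost activity as well as add it. No measurement shown gives a reason for the fall to compound 4.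

On these data alone, it remains open which part of the 2-(1H-imidazol-1-yl)ethoxy group carries the gain, the five-membered aromatic ring or the ethoxy chain that holds it, and a plain methoxy group or a longer chain ending in the same ring would help to separate the two. As far as these compounds go, it is equally open whether the loss belongs to ethoxycarbonyl alone or would also follow with a carboxylic acid or a primary amide at this position.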